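The compounds below may be only part of what the source reports. "The series", "measured", "known", "first", "only" and "open" are said of these compounds alone.

Measured in a functional assay on SK-MEL-28 cells (Homo sapiens) for cytotoxicity; a lower number here means a stronger inhibitor, a higher number a weaker inhibitor:
- Compound 1 `COc1cc(/C=C/c2ccc3ccccc3n2)cc(OC)c1OC`: 398 nM
- Compound 2 `COc1cc(/C=C\c2cnc3ccccc3c2)cc(OC)c1OC`: 398 nM

Compound 2 stands level with compound 1, and the two values match at the digits reported. The next compound, compound 3 `COc1cc(/C=C/c2cnc3ccccc3c2)cc(OC)c1OC`, keeps the atoms and bonds of compound 2 and changes only the geometry: the two compounds have the same atoms and bonds and differ only in configuration as drawn: 1 of 1 stereo elements differ; a double bond is drawn Z in compound 2 and E in compound 3. Going by the values given here, no measured pair in this small set isolates a change of this kind, so the data give little direct support for judging its size. In this assay, a moderate move towards weaker inhibition is expected, although a result within the usual scatter would be no surprise. The estimated change is a 1.6-fold higher number from compound 2 to compound 3 (0.20 log units; within the scatter). For compound 3, the expected half-maximal inhibitory concentration is 630 nM, with an estimated range from 150 nM to 3000 nM.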

Compound 3, half-maximal inhibitory concentration: > 3160 nM
Compound 3: only a limit was reported; the forecaster's own chance of this, stated with the estimate: 4%; middle value at least 5.0-fold (0.70 log units) from the limit.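

In this assay, going by these compounds alone, the configuration of the double bond proves to matter on its own, a point the earlier compounds could not show: going from Z to E gives an at least 7.9-fold higher number from compound 2 to compound 3 (0.89 log units; beyond the scatter). On these data alone, compound 3 has only a limit, > 3160 nM, and not a number, so the step sets a minimum and its full size stays unknown. The step can be assigned to the double bond alone because nothing else separates the pair: the fact that compounds 2 and 3 differ only in the configuration as drawn

The compounds shown leave open whether the configuration would matter as much in compound 1, whose double bond is drawn E and whose Z partner is not among them. They also leave open how a substituent such as an amine or a hydroxyl group on the shared core would behave in either configuration.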